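A few compounds are considered here, and "the series" means these few. Any claim that something is new, unique, unknown or untested is made for them only; others in the source may bear on it.

Compound 1 `COc1ccc(C2=NN(C(=O)CO[N+](=O)[O-])C(c3ccco3)C2)cc1OC`: 32%
Compound 2 `COc1ccc(C2=NN(C(=O)CO[N+](=O)[O-])C(c3c(Cl)cccc3Cl)C2)cc1OC`: 40%

Both were tested in a functional assay on the whole organism (strain albino) for inhibition, with Rattus norvegicus as the target, read by paw edema, with stated times of 30 min and 1 h, at a dose of 100 mg/kg by the oral route; on this read-out lower numbers stand for less inhibition and higher numbers for more inhibition at the one dose given (going by the name of the read-out). Compound 2 stands highest of the two numbers, with compound 1 nearest at a number 8 percentage points higher from compound 1 to compound 2 (within the scatter), a difference that the scatter covers. Compound 3 `COc1ccc(C2=NN(C(=O)C(C)O[N+](=O)[O-])C(c3c(Cl)cccc3Cl)C2)cc1OC` differs from compound 2 only by methyl in place of hydrogen on a saturated chain carbon bound to a carbonyl carbon and an oxygen on an unsaturated carbon. Among the compounds with values here, no measured step touches this position; the only step known, from compound 1 to compound 2, concerns a different part of the molecule. With no guidance from the data, the expected step is none beyond the scatter, no change at the digits printed from compound 2 to compound 3 (within the scatter). Compound 3 is therefore estimated at 40%, within 25% to 55%.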

Compound 3, a percentage reported as inhibition, in the whole organism at one dose (the size of the read-out at that dose, not a potency): 47%
Compound 3: the middle estimate sits 7 percentage points below what was measured; measured number inside the range.
By their numbers in this assay, from the lowest: compounds 1, 2 and 3 (each within the scatter of the next, the first and the last beyond it).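

Methyl in place of hydrogen on this saturated chain carbon gives, in this assay, a number 7 percentage points higher from compound 2 to compound 3 (within the scatter). Within the data shown here, the earlier step concerned a different part of the molecule, so this is the first reading at this position, and it shows that the position accepts a methyl with no shift beyond the scatter. Nothing available explains the result.

From the compounds shown here alone, whether an ethyl group or a longer chain on this carbon would move the number beyond the scatter remains open. So does the effect of the same methyl when furan-2-yl replaces 2,6-dichlorophenyl.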